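The compounds below may be only part of what the source reports. "The series", "measured", "known", "first", "only" and "open" are said of these compounds alone.

Working notes on the series. Two members of the shared core have been measured in a functional assay on the whole organism for inhibition, with Mus musculus as the target, at a dose of 32 mg/kg by the oral route; a higher number here means more inhibition at the dose given (going by the name of the read-out), a lower number less inhibition. Compound 1 `CCSc1ccc2c(c1)c(O)c(C(=O)N(C)c1ccccc1)c(=O)n2C` gives 100% in this assay. Within the data shown here, compound 2 `CN(C(=O)c1c(O)c2cc(Oc3ccccc3)ccc2n(C)c1=O)c1ccccc1` gives 26% in this assay, the lower of the two numbers on hand; the step of a number 74 percentage points lower from compound 1 to compound 2 (beyond the scatter) is the only measured step so far, and it lies well beyond the scatter. Among the measured compounds shown here, compound 2 therefore stands at the bottom of the pair, with compound 1 as its only neighbour.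

The next member is compound 3 `CN(C(=O)c1c(O)c2cc(S(C)(=O)=O)ccc2n(C)c1=O)c1ccccc1`. The change from compound 2 to compound 3 is methylsulfonyl in place of phenoxy on an aromatic carbon. For the measured compounds named here, no measured step involves methylsulfonyl, so the single step that bears on this move does so only indirectly: from compound 1 to compound 2 the exchange of ethylsulfanyl for phenoxy cost a large amount, which shows that this position of the core is sensitive to what sits on it, without saying which way the present change will go. The size of the step of a number 24 percentage points higher from compound 2 to compound 3 (beyond the scatter) is an estimate, and only weakly founded. Compound 3 is expected to give 50% in this assay, within a wide range from 10% to 95%.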

Compound 3, a percentage reported as inhibition, in the whole organism at one dose (the size of the read-out at that dose, not a potency): 0%
The estimate for compound 3 lay 50 percentage points above the measured number, outside the stated range (below it).
By their numbers in this assay, from the lowest: compound 3; then compound 2; then compound 1.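

In this assay, the step of a number 26 percentage points lower from compound 2 to compound 3 (beyond the scatter) shows that removing the phenoxy ring does not recover the read-out at this position, and methylsulfonyl, which carries no ring, leaves compound 3 at the bottom of the three. The step of a number 100 percentage points lower from compound 1 to compound 3 (beyond the scatter) adds that sulfur attached to this aromatic carbon is not enough to keep the read-out, since ethylsulfanyl and methylsulfonyl both carry it, yet only ethylsulfanyl stands at the top, with its steps to both other groups beyond the scatter. The measurements offer no independent evidence on why these groups differ, so the ranking remains an observation without an explanation.

On these data alone, three groups at one position cannot show which feature of ethylsulfanyl goes with the high number, so it remains open whether methylsulfanyl, propylsulfanyl or ethoxy would hold it, and how an amine or a carboxylic acid would compare there. These are also single-dose whole-organism numbers rather than potencies, so the compounds leave open how the ranking would look at other doses or by other routes.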